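From piperidin-1-yl to azetidin-1-yl on a shared core

A few compounds are considered here, and "the series" means these few. Any claim that something is new, unique, unknown or untested is made for them only; others in the source may bear on it.

Of the compounds shown here, three sharing one core have been tested in a functional assay on MCF7 cells (Homo sapiens) for inhibition, read by sulforhodamine B assay; on this read-out higher numbers stand for weaker inhibition and lower numbers for stronger inhibition. Compound 1 `O=C1C(Nc2ccc(I)cc2)=CC(=O)c2c1nc1n2[C@H]2OC[C@@H](O)[C@H]2OC1`, carrying (4-iodophenyl)amino, gives 3890 nM. Compound 2 `Cc1ccc(NC2=CC(=O)c3c(nc4n3[C@H]3OC[C@@H](O)[C@H]3OC4)C2=O)cc1`, carrying (4-methylphenyl)amino, is reported only as a limit, > 4000 nM. Compound 3 `O=C1C(N2CCCCC2)=CC(=O)c2c1nc1n2[C@H]2OC[C@@H](O)[C@H]2OC1`, carrying piperidin-1-yl, is also reported only as a limit, > 8000 nM.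

In compound 4 `O=C1C(N2CCC2)=CC(=O)c2c1nc1n2[C@H]2OC[C@@H](O)[C@H]2OC1`, azetidin-1-yl takes the place of piperidin-1-yl on a double-bonded ring carbon: azetidin-1-yl in place of piperidin-1-yl on a double-bonded ring carbon. For the measured compounds named here, no measured step swaps one such ring for another, so the evidence is indirect. The nearest steps are those that introduced piperidin-1-yl. One gave an at least 2.0-fold higher number from compound 1 to compound 3 (0.31 log units; beyond the scatter), and the other gave a step that the two limits leave unreadable from compound 2 to compound 3. Neither shows what a change in ring size does, so no step beyond the scatter is expected in either direction, and another limit is quite likely. The expected change is a number no higher from compound 3 to compound 4 (the limit leaves the size open). For compound 4, the estimated value is 8000 nM, with an expected range from 3000 nM to 25000 nM.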

Compound 4, half-maximal inhibitory concentration: > 16000 nM
Compound 4 ended at the assay's limit (the forecaster's own chance of this, stated with the estimate: 60%); middle value at least 2.0-fold (0.30 log units) from the limit.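

In this assay, compound 4 gives > 16000 nM, which is a limit and not a number. Putting azetidin-1-yl in place of (4-iodophenyl)amino on the double-bonded ring carbon gives an at least 4.1-fold higher number from compound 1 to compound 4 (0.61 log units; beyond the scatter), and piperidin-1-yl in the same place gives an at least 2.0-fold higher number from compound 1 to compound 3 (0.31 log units; beyond the scatter), so a four-membered and a six-membered non-aromatic ring both read weaker here than the group in compound 1, the only compound shown with an actual number. The steps to compound 4 from compound 3 and from compound 2 cannot be read, as both ends of each are limits.

On these data alone, what ring size itself does at this position therefore stays open. Also open, as far as these compounds go, is whether pyrrolidin-1-yl, morpholin-4-yl or a simple open-chain dimethylamino group would give a real number rather than another limit.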